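The compounds below may be only part of what the source reports. "The series", "measured", "known", "first", "only" and "open" are said of these compounds alone.

In a functional assay on NCI-H3122 cells (Homo sapiens) for inhibition, read by CellTiter-Glo, with a stated time of 72 h (on this read-out lower numbers stand for stronger inhibition of growth and higher numbers for weaker inhibition of growth), compound 1 `C=CC(=O)Nc1cc(Nc2ncc(Cl)c(Nc3ccccc3S(=O)(=O)C(C)C)n2)c(OC)cc1N1CCN(C)CC1` gives 33 nM, the highest of the two plain numbers shown. Compound 3 `C=CC(=O)Nc1cc(Nc2ncc(Cl)c(Nc3ccccc3S(=O)(=O)C(C)C)n2)c(OC)cc1N1CCCCC1` gives 29 nM, and the step of a 1.1-fold lower number from compound 1 to compound 3 (0.06 log units; within the scatter) lies within the scatter. Compound 2 `C=CC(=O)Nc1cc(Nc2ncc(Cl)c(Nc3ccccc3S(=O)(=O)C(C)C)n2)c(OC)cc1N1CCCN(C)CC1` is recorded only as a limit of the assay, < 0.3 nM, so the step of an at least 110-fold lower number from compound 1 to compound 2 (2.04 log units; beyond the scatter) is known only as a bound (the limit of < 0.3 nM in this assay, at which 1 of the 3 values shown sits). Compound 4 `C=CC(=O)Nc1cc(Nc2ncc(Cl)c(Nc3c(F)cccc3F)n2)c(OC)cc1N1CCN(C)CC1` arises from compound 1 by 2,6-difluorophenyl in place of 2-(isopropylsulfonyl)phenyl on a nitrogen on an aromatic ring. Every measured step here alters the ring on the aromatic carbon, and none touches the group on the nitrogen on an aromatic ring that changes in compound 4, so they offer no direct guide. Lacking such a guide, a moderate weakening is estimated for compound 4, a 3.6-fold higher number from compound 1 to compound 4 (0.56 log units; beyond the scatter), with an expected 120 nM between 15 nM and 1200 nM.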

Compound 4, concentration for 50% growth inhibition: 2900 nM
For compound 4 the middle estimate is 24-fold (1.38 log units) below the measured one; measured number outside the range, above it.
By their numbers in this assay, from the lowest: compounds 3 and 1 (each within the scatter of the next); then compound 4. At a limit, below all of these: compound 2.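

In this assay, the change on a nitrogen on an aromatic ring gives an 88-fold higher number from compound 1 to compound 4 (1.94 log units; beyond the scatter). Among these compounds, the earlier steps altered only the ring on the aromatic carbon, so this is the first sign that growth inhibition also depends strongly on the group at this nitrogen. Nothing measured here accounts for the step. As far as these compounds go, it remains open whether a phenyl bearing methylsulfonyl or a sulfonamide instead of isopropylsulfonyl would keep the number of compound 1. Also open, from the compounds shown here alone, is whether 4-methyl-1,4-diazepan-1-yl would have a similar effect alongside 2,6-difluorophenyl.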